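This account rests on a few compounds, and the source may have more. Where it says the series, first, only, none or still open, it means among the compounds named here.

Compounds measured so far in a functional assay (Pituitary gland cell) with Rattus norvegicus as the target; on this read-out lower numbers stand for an effect already at smaller amounts and higher numbers for an effect only at larger amounts of compound:
- compound 1 `CC(C)(N)CC(=O)N[C@@H]1CCc2ccccc2N(Cc2ccc(-c3ccccc3C(=O)O)cc2)C1=O`: 3 uM
- compound 2 `CC(C)(N)CC(=O)N[C@@H]1CCc2ccccc2N(Cc2ccc(-c3ccccc3-c3nnn(Cc4ccccc4)n3)cc2)C1=O`: 1 uM
- compound 3 `CC(C)(N)CC(=O)N[C@@H]1CCc2ccccc2N(Cc2ccc(-c3ccccc3-c3nnnn3Cc3ccccc3)cc2)C1=O`: 0.7 uM

Compound 3 gives the lowest of the three numbers in this assay. Against compound 1 the gap is a 4.3-fold lower number from compound 1 to compound 3 (0.63 log units; beyond the scatter), against compound 2 it is only a 1.4-fold lower number from compound 2 to compound 3 (0.15 log units; within the scatter), so compound 2 and compound 3 cannot be ranked against each other.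

Compound 4 `COC(=O)c1ccccc1-c1ccc(CN2C(=O)[C@H](NC(=O)CC(C)(C)N)CCc3ccccc32)cc1` is compound 3 with one change: methoxycarbonyl in place of 1-benzyl-1H-tetrazol-5-yl on an aromatic carbon.

Within the data shown here, no measured step shows a methoxycarbonyl group at this place, so the expectation rests on the two steps that leave this position: a 3.0-fold lower number from compound 1 to compound 2 (0.48 log units; beyond the scatter) and a 4.3-fold lower number from compound 1 to compound 3 (0.63 log units; beyond the scatter). Among the measured compounds shown here, both replacements of carboxy by a benzyl-bearing tetrazole gave a modestly lower number; the only other group seen at the position, carboxy in compound 1, gave the highest number of the set. Methoxycarbonyl lies nearer to carboxy than to the tetrazoles in what is counted, and the step from compound 3 to compound 4 is therefore expected to go back toward the number of compound 1, estimated as a 4.3-fold higher number from compound 3 to compound 4 (0.63 log units; beyond the scatter). Compound 4 is accordingly estimated at 3 uM in this assay, within a range from 1 uM to 10 uM.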

Compound 4, concentration for half-maximal effect: 2 uM
Beside the measured number, compound 4's estimate is 1.5-fold (0.18 log units) above it; the measured number falls inside the stated range.
By their numbers in this assay, from the lowest: compounds 3, 2, 4 and 1 (each within the scatter of the next, the first and the last beyond it).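

In this assay, methyl in place of hydrogen on the oxygen next to the carbonyl group gives a step that cannot be told from repeat scatter (a 1.5-fold lower number from compound 1 to compound 4 (0.18 log units; within the scatter)), so the hydrogen of the carboxy group makes no difference this read-out can resolve. The position on the aromatic carbon, ortho to a large group, takes both methoxycarbonyl with 4 heavy atoms and 1-benzyl-1H-tetrazol-5-yl with 12 heavy atoms at only a modest cost (a 2.9-fold higher number from compound 3 to compound 4 (0.46 log units; beyond the scatter)), while the step from the 2-benzyl-2H-tetrazol-5-yl isomer stays within the scatter (a 2.0-fold higher number from compound 2 to compound 4 (0.30 log units; within the scatter)), so only the 1-benzyl isomer is separated from the ester. Nothing given here accounts for these steps.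

The compounds shown leave open whether the benzyl group or the tetrazole ring carries the step from methoxycarbonyl to 1-benzyl-1H-tetrazol-5-yl, which a tetrazole with a hydrogen or a methyl in place of the benzyl would separate. They also leave open how a primary carboxamide, a hydroxymethyl group or a longer ester such as benzyloxycarbonyl would fall at this position.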